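Swapping Phenyl for Cyclopentyl on a Thiophene-Bearing Amine

The compounds below may be only part of what the source reports. "The series", "measured", "known", "first", "only" and "open" are said of these compounds alone.

Measured so far:
Compound 1 `CCCc1csc(CN[C@@H]2C[C@H]3C[C@@H]([C@H]2C)C3(C)C)c1`: 12500 nM
Compound 2 `C[C@H]1[C@H](NCc2sccc2-c2ccccc2)C[C@H]2C[C@@H]1C2(C)C`: 12500 nM
Compound 3 `C[C@H]1[C@H](NCc2ccoc2)C[C@H]2C[C@@H]1C2(C)C`: > 100000 nM

Three compounds share the same bicyclic amine core and differ only in the group attached to the amine. In an ADME assay on MDCK cells (Canis lupus familiaris) for cytotoxicity, read by microscopy, with a stated time of 48 h (a lower number here means that less compound is tolerated, a higher number that more compound is tolerated), compound 1 gives 12500 nM. In this assay compound 2 gives 12500 nM, which sits level with compound 1 within the usual scatter. For compound 3 the result in this assay is a limit of the assay, > 100000 nM, not a number (the limit of > 100000 nM in this assay, at which 1 of the 3 values shown sits).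

Compound 4 `C[C@H]1[C@H](NCc2sccc2C2CCCC2)C[C@H]2C[C@@H]1C2(C)C` has not yet been measured. It differs from compound 2 in one place: cyclopentyl in place of phenyl on an aromatic carbon. The phenyl leaves and a cyclopentyl enters, a smaller, non-aromatic ring. For the measured compounds named here, no step between measured compounds speaks to such a change, so the expectation rests on compound 2 alone. The step from compound 2 to compound 4 in this assay is expected to be no change at the digits printed from compound 2 to compound 4 (within the scatter), which is no change beyond the scatter. Compound 4 is therefore estimated at 12500 nM, within a range from 5000 nM to 40000 nM.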

Compound 4, minimum cytotoxic concentration: 12500 nM
Estimate against measurement, compound 4: no gap at the digits printed; the range from low to high includes it.
By their numbers in this assay, from the lowest: compounds 1, 2 and 4 (each within the scatter of the next). At a limit, above all of these: compound 3.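

At this position, on an aromatic carbon of a five-membered aromatic ring with 1 sulfur, cyclopentyl in place of phenyl gives no change at the digits printed from compound 2 to compound 4 (within the scatter) in this assay. For this pair of groups, then, a six-membered aromatic ring and a five-membered non-aromatic ring of carbon only are tolerated alike by the cells. For the compounds shown here, this is the first step between measured compounds that differ in one place, and both of its ends are numbers rather than limits.

From the compounds shown here alone, with only these two groups compared at this place, it stays open whether an amine, a carboxylic acid or a longer chain there would shift the value. Compound 3 differs from compound 2 in more than one place, so its result, a limit of the assay, cannot be tied to any single change: the limit of > 100000 nM in this assay, at which 1 of the 4 values shown sits.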